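The source may report more compounds than this note shows. Statements on the series, on what has been measured and on what is new or still open speak of the compounds shown alone.

Working notes on the series. In a functional assay on K562 cells (Homo sapiens) for inhibition, read by MTT assay, with a stated time of 72 h (on this read-out lower numbers stand for stronger inhibition of growth and higher numbers for weaker inhibition of growth), compound 1 `Nc1n[nH]c2cccc(C#Cc3cccc(NC(=O)c4cccc(C(F)(F)F)c4)c3)c12` gives 1540 nM and compound 2 `Cc1ccc(C(=O)Nc2cccc(C#Cc3cccc4[nH]nc(N)c34)c2)cc1C(F)(F)F` gives 2350 nM. Compound 3 `Nc1n[nH]c2cccc(C#Cc3cccc(C(=O)Nc4cccc(C(F)(F)F)c4)c3)c12` gives 3470 nM, which places it at the upper end of these numbers. It is level with compound 2 within the scatter, while compound 1 lies lower, beyond the scatter.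

The next change leads to compound 4 `Cc1cn(-c2cc(NC(=O)c3cccc(C#Cc4cccc5[nH]nc(N)c45)c3)cc(C(F)(F)F)c2)cn1`: 4-methyl-1H-imidazol-1-yl in place of hydrogen on an aromatic carbon. The new group sits meta to a trifluoromethyl group.

Among the measured compounds shown here, only one measured step bears on this, a 1.5-fold higher number from compound 1 to compound 2 (0.18 log units; within the scatter), where methyl replaces hydrogen on an aromatic carbon. For the measured compounds named here, that step is small and much lighter than the change at hand, and no measured compound carries 4-methyl-1H-imidazol-1-yl. The data therefore fix neither size nor direction, and any expectation in this assay is weakly founded.

The expected step is a 4.3-fold lower number from compound 3 to compound 4 (0.64 log units; beyond the scatter), towards stronger inhibition of growth, though a result within the scatter would not surprise. Compound 4 is estimated at 800 nM, with an expected range from 100 nM to 4000 nM.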

Compound 4, concentration for 50% growth inhibition: 150 nM
Estimate against measurement, compound 4: 5.3-fold (0.73 log units) above; measured number inside the range.
By their numbers in this assay, from the lowest: compound 4; then compounds 1, 2 and 3 (each within the scatter of the next, the first and the last beyond it).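

In this assay, placing 4-methyl-1H-imidazol-1-yl on this aromatic carbon, meta to a trifluoromethyl group, gives a 23-fold lower number from compound 3 to compound 4 (1.36 log units; beyond the scatter), a large move towards stronger inhibition of growth. Among the compounds shown here, the only earlier step, a 1.5-fold higher number from compound 1 to compound 2 (0.18 log units; within the scatter), with methyl in place of hydrogen on an aromatic carbon, gave no sign that a single substitution could shift the number this far. The compounds shown offer no measurement that accounts for the size of this step.

As far as these compounds go, it remains open whether the five-membered aromatic ring itself is needed, or whether an amine or a carboxylic acid at the same place would give a similar step. From the compounds shown here alone, it is also open whether the same substitution would carry over to the reversed amide of compound 1.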